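Inverting an Epoxide Pair in a Glycosylated Macrocycle

The compounds below may be only part of what the source reports. "The series", "measured", "known", "first", "only" and "open" are said of these compounds alone.

Measured compounds:
compound 1 `CC(=O)O[C@@H]1[C@H](OC/C2=C/[C@@H]3[C@@H](C(C)C)CC=C(C)[C@@H]3C[C@H](OC(=O)/C=C/c3cn(C)cn3)[C@]3(C)C=C[C@@]2(O)O3)OC[C@@H](O)[C@H]1O` — 20 nM
compound 2 `CC(=O)O[C@@H]1[C@H](OC/C2=C/[C@@H]3[C@@H](C(C)C)CC=C(C)[C@@H]3C[C@H](OC(=O)/C=C/c3cn(C)cn3)[C@]3(C)C=C[C@@]2(OCCO)O3)OC[C@@H](O)[C@H]1O` — 20 nM
compound 3 `CO[C@]12C=C[C@](C)(O1)[C@@H](OC(=O)/C=C/c1cn(C)cn1)C[C@@H]1[C@H](/C=C\2CO[C@@H]2OC[C@@H](O)[C@@H](O)[C@@H]2OC(C)=O)[C@@H](C(C)C)C[C@@H]2O[C@@]21C` — 30 nM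

In a functional assay on MCF7 cells (Homo sapiens), read by ELISA, with a stated time of 20 h (on this read-out lower numbers stand for stronger inhibition and higher numbers for weaker inhibition), compound 1 gives 20 nM, and compound 2 gives 20 nM; the step of no change at the digits printed from compound 1 to compound 2 (within the scatter). Compound 3 gives 30 nM in this assay, a number not separated from those of compound 1 or compound 2 beyond the scatter.

Compound 4 `CO[C@]12C=C[C@](C)(O1)[C@@H](OC(=O)/C=C/c1cn(C)cn1)C[C@@H]1[C@H](/C=C\2CO[C@@H]2OC[C@@H](O)[C@@H](O)[C@@H]2OC(C)=O)[C@@H](C(C)C)C[C@H]2O[C@@]12C` differs from compound 3 as follows: the two compounds have the same atoms and bonds and differ only in configuration as drawn: 2 of 14 stereo elements differ; a stereocentre at a saturated ring carbon is drawn S in compound 3 and R in compound 4; a stereocentre at a saturated ring carbon is drawn R in compound 3 and S in compound 4. Among the measured compounds shown here, no measured step concerns a change in configuration; the single step available, from compound 1 to compound 2, is a substituent change and does not bear on this one. With no guide from the data, compound 4 is expected to stay near compound 3, with a wide range. The estimated step is a 1.3-fold higher number from compound 3 to compound 4 (0.12 log units; within the scatter). Compound 4 is therefore estimated at 40 nM, between 15 nM and 150 nM.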

Compound 4, half-maximal inhibitory concentration: 300 nM
Estimate against measurement, compound 4: 7.5-fold (0.88 log units) below, and the stated range ends below it.
By their numbers in this assay, from the lowest: compounds 1, 2 and 3 (each within the scatter of the next); then compound 4.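

In this assay the inversion gives a 10-fold higher number from compound 3 to compound 4 (1.00 log units; beyond the scatter), the only step shown that lies beyond the scatter. This shows that the arrangement at these two saturated ring carbons matters to the read-out, even though no atom enters or leaves. The shift can be assigned to configuration alone because of one fact: the fact that compounds 3 and 4 differ only in the configuration as drawn

On these data alone, whether inverting just one of the two stereocentres would produce the same shift stays open. So does how an amine or a carboxylic acid in place of the 2-hydroxyethyl group would read out on either configuration.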